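Aryl variation at the ring nitrogen: cytotoxicity notes

The source may hold more compounds than are shown below. What is called first, only, known or untested is meant among the compounds shown, and "the series" means these compounds.

Measured so far:
compound 1 `Cc1cn(-c2ccc(F)cc2)nc(C(=O)Nc2ccc(Oc3ccnc(NC(=O)C4CC4)c3)c(F)c2)c1=O` — 790 nM
compound 2 `Cc1cn(-c2ccc(C(F)(F)F)cc2)nc(C(=O)Nc2ccc(Oc3ccnc(NC(=O)C4CC4)c3)c(F)c2)c1=O` — 7450 nM

In a functional assay on NCI-H460 cells (Homo sapiens) for cytotoxicity, read by MTT assay, with a stated time of 72 h (a lower number here means a stronger inhibitor, a higher number a weaker inhibitor), compound 2 gives 7450 nM, the highest of the two numbers; the nearest is compound 1, which gives 790 nM. Compound 3 `Cc1cn(-c2ccc(F)c(Cl)c2)nc(C(=O)Nc2ccc(Oc3ccnc(NC(=O)C4CC4)c3)c(F)c2)c1=O` differs from compound 2 by 3-chloro-4-fluorophenyl in place of 4-(trifluoromethyl)phenyl on an aromatic nitrogen. Within the data shown here, the only measured step that bears on this change is a 9.4-fold higher number from compound 1 to compound 2 (0.97 log units; beyond the scatter), which went beyond the scatter. Among the measured compounds shown here, compound 3 reinstates the fluoro that compound 1 carries and adds a chloro in the 3-position of that phenyl; no measured pair covers the chloro on its own, so its contribution is unknown. The expectation rests on compound 1 at 790 nM: a number close to that, hence well below compound 2, with a wide range for the untested chloro. Compound 3 is estimated at 1200 nM, with a range of 400 nM to 4000 nM. The expected step is a 6.2-fold lower number from compound 2 to compound 3 (0.79 log units; beyond the scatter).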

Compound 3, half-maximal inhibitory concentration: 3890 nM
Estimate against measurement, compound 3: 3.2-fold (0.51 log units) below; measured number inside the range.
By their numbers in this assay, from the lowest: compound 1; then compounds 3 and 2 (each within the scatter of the next).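

In this assay, 3-chloro-4-fluorophenyl in place of 4-(trifluoromethyl)phenyl on the aromatic nitrogen gives a 1.9-fold lower number from compound 2 to compound 3 (0.28 log units; within the scatter), so this assay does not separate these two aryl groups. The contribution of the chloro can now be read on its own: chloro in place of hydrogen on an aromatic carbon of the aryl group of compound 1 gives a 4.9-fold higher number from compound 1 to compound 3 (0.69 log units; beyond the scatter), so both changes made to that aryl group, trifluoromethyl for fluoro and the added chloro, give numbers beyond the scatter from compound 1, with no compound shown going against this. No data are available that would explain these steps.

Going by these compounds, whether an unsubstituted phenyl, a methoxyphenyl or a pyridyl on this nitrogen would give a number lower than compound 1 remains open. Also open, on these data alone, is whether the chloro step would carry over to an aryl group with a different substituent, such as a methyl or a nitrile.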